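The compounds below may be only part of what the source reports. "The series", "measured", "known", "first", "only" and "open" are said of these compounds alone.

Working notes on the series, read in an ADME assay on HepG2 2.2.15 cells (Homo sapiens) for cytotoxicity, read by MTT assay, with a stated time of 8 days; a higher number here means that more compound is tolerated, a lower number that less compound is tolerated. Compound 1 (`O=c1c(CO)cc(-c2ccc(F)nc2F)nn1Cc1ccc(Cl)cc1`) stands at > 100000 nM and this is a limit of the assay, not a number. Compound 2 (`COC(=O)C1=C(C)NC(c2ncc(F)cc2F)=N[C@H]1c1ccc(F)cc1Cl`) stands at > 5000 nM and this is likewise a limit. For the measured compounds named here, no number has been measured yet, and no step between measured compounds is available for scale. Compound 3 (`CC(C)c1cc(-c2ccc(F)nc2F)nn(Cc2ccc(Cl)cc2)c1=O`) has isopropyl in place of hydroxymethyl on an aromatic carbon of the core of compound 1 isopropyl in place of hydroxymethyl on an aromatic carbon and nothing else changes. The estimated change is an at least 2.0-fold lower number from compound 1 to compound 3 (0.30 log units; that floor lies within the scatter) in the direction of less compound tolerated, and another limit reading is quite possible. This expectation rests only on the structural change and on the limit of compound 1 at > 100000 nM in this assay so it is loose. For compound 3 the estimated half-maximal cytotoxic concentration is 50000 nM with an expected range from 15000 nM to 150000 nM as the working figure.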

Compound 3, half-maximal cytotoxic concentration: 56700 nM
Compound 3: the middle estimate sits 1.1-fold (0.05 log units) below what was measured; measured number inside the range.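

For the compounds shown here, compound 3 gives the first true number of the series in this assay: 56700 nM, so this position now has a reading inside the assay's range. Isopropyl in place of hydroxymethyl on this aromatic carbon, opposite the ring nitrogen, removes the hydrogen-bond donor and acceptor of the group and gives an at least 1.7-fold lower number from compound 1 to compound 3 (0.24 log units; that floor lies within the scatter). That step is only a floor, and its full size stays unknown since one of its ends is a limit: the limit of > 100000 nM in this assay, at which 1 of the 3 values shown sits.

As far as these compounds go, whether the step goes with the loss of the hydroxyl or with the branched carbon chain remains open. From the compounds shown here alone, how a methyl, a methoxy or an aminomethyl group on this carbon would read is also open.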